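The compounds below may be only part of what the source reports. "The series", "measured", "known", "first", "only" and "open" are said of these compounds alone.

Compound 1 `COc1ccc(C(=O)Nc2cc(-c3ccccc3)nn2-c2ccccc2)cc1` — 420 nM
Compound 2 `O=C(Nc1cc(-c2ccccc2Cl)nn1-c1ccccc1)c1ccccc1` — > 10000 nM, a limit
Compound 3 `O=C(Nc1cc(-c2ccccc2)nn1-c1ccccn1)c1ccccc1` — > 10000 nM, a limit

All three were tested in an assay on HEK293 cells for displacement of a labelled ligand from metabotropic glutamate receptor 5 (Rattus norvegicus); on this read-out higher numbers stand for weaker inhibition and lower numbers for stronger inhibition. Compound 1 is the only one of the three to give an actual number, 420 nM. For compound 2 the assay reports only a limit, > 10000 nM. For compound 3 likewise only a limit is reported, > 10000 nM. So (the limit of > 10000 nM in this assay, at which 2 of the 3 values shown sit), and compound 1 stands alone as the single measured value. No two of these compounds differ in just one place, so none of them provides a measured step.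

Compound 4 `Cc1ccc(C(=O)Nc2cc(-c3ccccc3)nn2-c2ccccc2)cn1` has not yet been measured. It differs from compound 1 in one place: 6-methylpyridin-3-yl in place of 4-methoxyphenyl on a carbonyl carbon. The amide and the shared core remain as in compound 1. Among the measured compounds shown here, with no measured step of this kind among the three, the expectation for compound 4 rests on compound 1 alone and on the structural change itself. In this assay a step of modest size is expected, toward weaker inhibition, if any beyond the usual scatter.

Compound 4 is therefore estimated at 800 nM, with a range from 250 nM to 3000 nM. That estimate means an expected step of a 1.9-fold higher number from compound 1 to compound 4 (0.28 log units; within the scatter) in this assay.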

Compound 4, inhibition constant: 3480 nM
Compound 4: the middle estimate sits 4.4-fold (0.64 log units) below what was measured; measured number above the stated range.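

The group on the carbonyl carbon is now shown to matter: in this assay, 6-methylpyridin-3-yl in place of 4-methoxyphenyl gives an 8.3-fold higher number from compound 1 to compound 4 (0.92 log units; beyond the scatter), whereas the earlier compounds offered no comparison of a change in one place. The two groups match in their counts of hydrogen-bond donors and acceptors, and that match did not preserve the number of compound 1, although compound 4 still gives a measured value rather than a limit. Nothing measured here accounts for the size of this step.

The change swaps two things at once, a ring carbon for a ring nitrogen and a methoxy group for a methyl group, and the compounds shown do not separate them: 4-methylphenyl or 6-methoxypyridin-3-yl on the same carbonyl carbon would show which of the two carries the step. Also open, from the compounds shown here alone, is how groups of a different kind would behave at this place, such as a cyclohexyl ring or a 4-aminophenyl group, and whether any of them could match or improve on compound 1.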